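The compounds below may be only part of what the source reports. "The series", "measured", "known", "first", "only" and "open" are said of these compounds alone.

Of the compounds shown here, three sharing one core have been measured in an assay on isolated protein for inhibition of phosphatidylinositol 4,5-bisphosphate 3-kinase catalytic subunit beta isoform (Homo sapiens); a higher number here means a weaker inhibitor, a lower number a stronger inhibitor. Compound 1 `CCN(CC)S(=O)(=O)c1cncc(-c2ccn3nc(N)nc3c2)c1` gives 25100000 nM. Compound 2 `CC(C)NS(=O)(=O)c1cncc(-c2ccn3nc(N)nc3c2)c1` gives 63100000 nM. Compound 3 `Nc1nc2cc(-c3cncc(S(N)(=O)=O)c3)ccn2n1` gives 39800000 nM. Among these three numbers compound 3 stands second highest: its nearest neighbour is compound 2 and its furthest is compound 1, and both of those distances lie within the usual scatter of this assay.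

Compound 4 `Nc1nc2cc(-c3cncc(S(=O)(=O)Nc4ccccc4)c3)ccn2n1` has not yet been measured. It differs from compound 3 by phenyl in place of hydrogen on a sulfonamide nitrogen; cut one bond further out, the same difference reads amino to anilino.

Within the data shown here, two measured steps touch the same sulfonamide nitrogen. The step of a 1.6-fold lower number from compound 2 to compound 3 (0.20 log units; within the scatter) shows that removing the isopropyl group changes little. The step of a 2.5-fold higher number from compound 1 to compound 2 (0.40 log units; beyond the scatter) is the only one beyond the scatter, and it is modest. The step of a 1.6-fold higher number from compound 1 to compound 3 (0.20 log units; within the scatter) again stays within the scatter. Among the measured compounds shown here, no measured compound carries an aromatic group on this nitrogen, so the phenyl is outside the tested range.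

Given how little the substituent on this nitrogen has mattered so far, compound 4 is expected to show a step of a 1.3-fold lower number from compound 3 to compound 4 (0.12 log units; within the scatter) in this assay, which may well stay within the scatter. The estimate for compound 4 is 30000000 nM, with a range from 5000000 nM to 150000000 nM.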

Compound 4, half-maximal inhibitory concentration: 31600000 nM
Beside the measured number, compound 4's estimate is 1.1-fold (0.02 log units) below it; the measured number falls inside the stated range.
By their numbers in this assay, from the lowest: compounds 1, 4, 3 and 2 (each within the scatter of the next, the first and the last beyond it).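

In this assay, the range of groups on the sulfonamide nitrogen now extends to an aromatic ring, and phenyl in place of hydrogen leaves only a small step (a 1.3-fold lower number from compound 3 to compound 4 (0.10 log units; within the scatter)) that lies within the scatter. Compared with the two alkyl-substituted compounds, the result is also within the scatter: phenyl in place of isopropyl gives a 2.0-fold lower number from compound 2 to compound 4 (0.30 log units; within the scatter) and anilino in place of diethylamino gives a 1.3-fold higher number from compound 1 to compound 4 (0.10 log units; within the scatter), so compound 4 cannot be separated from any of the other three, even though compound 1 and compound 2 are separated from each other beyond the scatter. Nothing available explains why the phenyl group makes so little difference at this position.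

What the compounds leave open is whether any group on this nitrogen can move the number well beyond the scatter, such as a carboxylic acid, an aminoethyl chain, or a phenyl ring carrying a methoxy group. They also leave open whether a change elsewhere on the shared core would have a larger effect than any seen on this nitrogen.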